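Hemolysis inhibition: two aryl hydrazones and a catechol variant

A few compounds are considered here, and "the series" means these few. Any claim that something is new, unique, unknown or untested is made for them only; others in the source may bear on it.

The series rests on a shared core, carried in compound 1 `O=C(CCc1nc2ccccc2c(=O)[nH]1)N/N=C/c1ccc([N+](=O)[O-])cc1` and compound 2 `O=C(CCCc1nc2ccccc2c(=O)[nH]1)N/N=C/c1ccc(Cl)cc1`. In a functional assay on cells (Erythrocyte, Homo sapiens) for inhibition, read by spectrophotometry and hemolysis, with a stated time of 10 min (a higher number here means a weaker inhibitor, a lower number a stronger inhibitor), compound 1 gives 54000000 nM. In this assay compound 2 gives 67000000 nM, the highest of the two numbers recorded so far, with compound 1 as its nearest neighbour; the two values sit within the scatter of each other, so the data do not separate the two compounds. Within the data shown here, no step between measured compounds is available for this series.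

Compound 3 `O=C(CCCc1nc2ccccc2c(=O)[nH]1)N/N=C/c1ccc(O)c(O)c1` is not yet measured. It differs from compound 2 as follows: 3,4-dihydroxyphenyl in place of 4-chlorophenyl on a carbon with a double bond to nitrogen. Nothing measured in the series bears on a change of this kind, so the step expected from compound 2 to compound 3 in this assay is one of no clear direction, and no movement beyond the scatter is assumed; the expected step is a 1.5-fold lower number from compound 2 to compound 3 (0.17 log units; within the scatter). Compound 3 is therefore estimated at 45000000 nM, within a range from 15000000 nM to 150000000 nM, the range kept wide for want of any step measured on this core.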

Compound 3, half-maximal inhibitory concentration: 300000000 nM
For compound 3 the middle estimate is 6.7-fold (0.82 log units) below the measured one; measured number above the stated range.
By their numbers in this assay, from the lowest: compounds 1 and 2 (each within the scatter of the next); then compound 3.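

In this assay, among these compounds, 3,4-dihydroxyphenyl in place of 4-chlorophenyl on a carbon with a double bond to nitrogen gives a 4.5-fold higher number from compound 2 to compound 3 (0.65 log units; beyond the scatter), the first step on this core that is beyond the scatter, so the group held at this place does bear on inhibition, and this change weakens it. The step also separates the entering group from the leaving one in count: 3,4-dihydroxyphenyl carries 2 hydrogen-bond donors and 2 hydrogen-bond acceptors where 4-chlorophenyl carries none, yet one step cannot tell whether the hydroxyl groups, the loss of the chlorine or both set the result. No measurement at hand speaks to the origin of the step.

Compounds 1 and 2 differ in both the chain and the aryl group, so the effect of either change alone cannot be read from them, and a 4-nitrophenyl group on the four-carbon-acid-derived chain of compound 2 would separate the two. Also open, going by these compounds, is how a single hydroxyl, as in 4-hydroxyphenyl, or an unsubstituted phenyl, a 4-methoxyphenyl or a 4-aminophenyl group would stand at this place relative to compound 2 and compound 3.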